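A few compounds are considered here, and "the series" means these few. Any claim that something is new, unique, unknown or untested is made for them only; others in the source may bear on it.

Compound 1 `COC(=O)c1ccc(-c2cnc(C(=O)CCc3ccc(-c4ccccc4)cc3)o2)nc1` was measured in an assay for inhibition of Fatty-acid amide hydrolase 1 (Rattus norvegicus) (a higher number here means a weaker inhibitor, a lower number a stronger inhibitor), and gave 2.2 nM. Compound 2 `COC(=O)c1ccc(-c2cnc(C(=O)CCc3ccc(COc4ccccc4)cc3)o2)nc1` differs from it only by a phenoxymethyl in place of phenyl on an aromatic carbon, and in this assay compound 2 gave 3.5 nM, so a 1.6-fold higher number from compound 1 to compound 2 (0.20 log units; within the scatter). Of these two numbers, compound 1 holds the one that is not the higher, though the pair lies within the scatter of one another.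

Compound 3 `O=C(O)c1ccc(-c2cnc(C(=O)CCc3ccc(-c4ccccc4)cc3)o2)nc1` is not yet measured. It differs from compound 1 in one place: hydrogen in place of methyl on an oxygen next to a carbonyl group. Among the compounds with values here, the only measured step, from compound 1 to compound 2, changes a group elsewhere on the molecule and says nothing about methyl against hydrogen on an oxygen next to a carbonyl group. Within the data shown here, with no measured step bearing on this change, the expectation rests on compound 1 alone, and a modest weakening, about at the edge of the scatter, is estimated: a 2.7-fold higher number from compound 1 to compound 3 (0.44 log units; beyond the scatter). Compound 3 is therefore expected to give 6 nM in this assay, within a range from 1.5 nM to 25 nM.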

Compound 3, inhibition constant: 14 nM
Compound 3: the middle estimate sits 2.3-fold (0.37 log units) below what was measured; the range from low to high includes it.
By their numbers in this assay, from the lowest: compounds 1 and 2 (each within the scatter of the next); then compound 3.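

In this assay, changing methoxycarbonyl to carboxy, with hydrogen in place of methyl on an oxygen next to a carbonyl group, gives a 6.4-fold higher number from compound 1 to compound 3 (0.80 log units; beyond the scatter) and so moves the number beyond the scatter, which the earlier change elsewhere on the molecule did not do. This position is therefore sensitive to the change, yet compound 3 at 14 nM remains a nanomolar inhibitor, so the methyl is not required for inhibition. Nothing in the data shown accounts for this rise.

Going by these compounds, only methyl and hydrogen are compared on this oxygen, so it remains open how an ethyl ester, with its longer chain, or a primary amide in place of the ester would behave. Also open, on these data alone, is whether the same change gives a step of similar size in compound 2, which carries phenoxymethyl.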